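Thiosemicarbazone cytotoxicity: from chloro-substituted to methyl-substituted imine

The source may hold more compounds than are shown below. What is called first, only, known or untested is meant among the compounds shown, and "the series" means these compounds.

Two compounds sharing one core were tested in a functional assay on MCF7 cells (Homo sapiens) for cytotoxicity, read by sulforhodamine B assay; on this read-out higher numbers stand for lower toxicity in this test and lower numbers for higher toxicity in this test. Compound 1 `CC1=CC[C@@H]([C@@](C)(O)CCCC(C)(C)NC(=S)N/N=C\c2ccccc2Cl)CC1` reached only the limit of the test, giving > 100000 nM. Among the measured compounds shown here, compound 2 `CC1=CC[C@@H]([C@@](C)(O)CCCC(C)(C)NC(=S)N/N=C\c2ccc(Cl)cc2)CC1` gave 44300 nM in this assay, which makes it the only compound with a number rather than a limit. For the measured compounds named here, the step of an at least 2.2-fold lower number from compound 1 to compound 2 (0.35 log units; beyond the scatter) is the single comparison available, and its size is bounded by the limit of > 100000 nM in this assay, at which 1 of the 2 values shown sits. Compound 3 `CC1=CC[C@@H]([C@@](C)(O)CCCC(C)(C)NC(=S)N/N=C(/C)c2ccccc2)CC1` differs from compound 2 by a group of 9 heavy atoms (8 carbon, 1 nitrogen; one six-membered aromatic ring of carbon only) in place of a group of 9 heavy atoms (7 carbon, 1 nitrogen, 1 chlorine; one six-membered aromatic ring of carbon only), on an amide-type nitrogen; in words, a group of 9 heavy atoms (8 carbon, 1 nitrogen; one six-membered aromatic ring of carbon only) in place of a group of 9 heavy atoms (7 carbon, 1 nitrogen, 1 chlorine; one six-membered aromatic ring of carbon only), on an amide-type nitrogen. Going by the values given here, no measured step covers this change, so the expected step of a 1.6-fold higher number from compound 2 to compound 3 (0.20 log units; within the scatter) is small and uncertain. Compound 3 is estimated at 70000 nM, within a range of 30000 nM to 200000 nM.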

Compound 3, concentration lethal to 50% of the cells: > 100000 nM
Compound 3 was reported as a limit; the forecaster's own chance of this, stated with the estimate: 35%; middle value at least 1.4-fold (0.15 log units) away from the limit.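

In this assay, putting the group of 9 heavy atoms with 8 carbon and 1 nitrogen in place of the group with 7 carbon, 1 nitrogen and 1 chlorine, on the amide-type nitrogen, gives an at least 2.2-fold higher number from compound 2 to compound 3 (0.35 log units; beyond the scatter). Among the compounds shown here, the earlier compounds showed only that the read-out changes when the chlorine-bearing group is altered, whereas this result shows that a group without chlorine at this place also leaves the read-out at the limit of the test. The full size of this step stays unknown, and the step between compound 1 and compound 3 cannot be read, because values at the limit are not numbers: the limit of > 100000 nM in this assay, at which 2 of the 3 values shown sit.

As far as these compounds go, the loss of the chlorine and the gain of the extra carbon arrive together in this single change, so their separate contributions remain open. From the compounds shown here alone, how a bromine or a methoxy group would read in place of the chlorine also remains open.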